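This account rests on a few compounds, and the source may have more. Where it says the series, first, only, none or still open, it means among the compounds named here.

Measured compounds:
Compound 1, `Cc1ccc(-c2ccccc2S(=O)(=O)N2CCC(N3CCC(C)CC3)CC2)cc1`, in a functional assay on DLD-1 cells (Homo sapiens) for antiproliferative activity, read by CellTiter-Glo, with a stated time of 72 h (a higher number here means a weaker inhibitor, a lower number a stronger inhibitor), compound 1 gives 366 nM.
Compound 2, `CC1CCN(C2CCN(S(=O)(=O)c3ccc(C#N)cc3)CC2)CC1`, in this assay compound 2 gives 2800 nM.
Compound 3, `CC1CCN(C2CCN(S(=O)(=O)c3ccccc3Br)CC2)CC1`, in this assay compound 3 gives 3 nM.

Compound 3 stands at the lowest number of the three. The step of a 120-fold lower number from compound 1 to compound 3 (2.09 log units; beyond the scatter) and the step of a 930-fold lower number from compound 2 to compound 3 (2.97 log units; beyond the scatter) both run downward into compound 3, so the two other compounds sit well apart from it, beyond the scatter.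

The next compound, compound 4, `CC1CCN(C2CCN(S(=O)(=O)c3ccccc3-c3ccc(C(F)(F)F)cc3)CC2)CC1`, departs from compound 3 by a single change: 4-(trifluoromethyl)phenyl in place of bromo on an aromatic carbon. Of the measured steps, the one that bears on this is the step from compound 1, whose corresponding aromatic carbon carries a 4-methylphenyl group, to compound 3, where that group is replaced by bromo: a 120-fold lower number from compound 1 to compound 3 (2.09 log units; beyond the scatter). Compound 4 goes the other way, putting an aryl group back in place of the bromo, and on that basis a large rise in the number is expected, of roughly the size seen in compound 1. The step from compound 2 concerns a different part of the molecule and offers no guide here.

The estimated step is a 100-fold higher number from compound 3 to compound 4 (2.00 log units; beyond the scatter). Compound 4 is therefore expected to give about 300 nM in this assay, within a range from 60 nM to 1500 nM.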

Compound 4, half-maximal inhibitory concentration: 122 nM
Compound 4: middle estimate off by 2.5-fold (0.39 log units), on the high side; the range from low to high includes it.
By their numbers in this assay, from the lowest: compound 3; then compound 4; then compound 1; then compound 2.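

In this assay, among the compounds shown here, the earlier compounds showed the loss from replacing bromo with only one aryl group, whereas a 41-fold higher number from compound 3 to compound 4 (1.61 log units; beyond the scatter) shows a second aryl group at this position also falling well short of bromo, so the lead of compound 3 holds against both 4-methylphenyl and 4-(trifluoromethyl)phenyl. For the compounds shown here, the new pair also gives the first reading of a change on the added phenyl ring itself: trifluoromethyl in place of methyl gives a 3.0-fold lower number from compound 1 to compound 4 (0.48 log units; beyond the scatter), which is beyond the scatter but modest, and recovers only a small part of the large loss seen on going from bromo to an aryl group. Nothing measured here explains either the large step or the modest one.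

The compounds shown leave open how other small groups on this aromatic carbon, such as chlorine, iodine or a methoxy group, would compare with the bromo of compound 3. They also leave open whether an amine or a carboxylic acid in place of trifluoromethyl on the added phenyl ring would bring the number closer to that of compound 3.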